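This account rests on a few compounds, and the source may have more. Where it says the series, first, only, none or still open, it means among the compounds named here.

Compound 3 `CN(C(=O)NC(=O)c1ccccc1F)c1nc(C(F)(F)F)c(C(=O)N/N=C/c2cccc(C(F)(F)F)c2)s1` gives 19.1 ug/mL in a functional assay on HeLa cells (Homo sapiens) for inhibition, read by MTT assay, with a stated time of 72 h (a higher number here means a weaker inhibitor, a lower number a stronger inhibitor), the highest number of the three shown. Compound 2 `CN(C(=O)NC(=O)c1ccccc1F)c1nc(C(F)(F)F)c(C(=O)N/N=C/c2ccccc2C(F)(F)F)s1` gives 10.1 ug/mL; the step of a 1.9-fold higher number from compound 2 to compound 3 (0.28 log units; within the scatter) lies within the scatter. Compound 1 `CN(C(=O)NC(=O)c1ccc(Cl)cc1Cl)c1nc(C(F)(F)F)c(C(=O)N/N=C/c2ccc(C(F)(F)F)cc2)s1` gives 7.99 ug/mL, a gap from compound 3 that is beyond the scatter. Compound 4 `CN(C(=O)NC(=O)c1ccccc1F)c1nc(C(F)(F)F)c(C(=O)N/N=C/c2ccc(C(F)(F)F)cc2)s1` differs from compound 3 by 4-(trifluoromethyl)phenyl in place of 3-(trifluoromethyl)phenyl on a carbon with a double bond to nitrogen. For the measured compounds named here, the one measured step that bears on a shift of the trifluoromethyl on this phenyl ring is a 1.9-fold higher number from compound 2 to compound 3 (0.28 log units; within the scatter), which stayed within the scatter; compound 1 carries 4-(trifluoromethyl)phenyl as compound 4 does but differs elsewhere too, so its value is not a clean comparison. For compound 4 no step beyond the scatter is expected, a 1.6-fold lower number from compound 3 to compound 4 (0.20 log units; within the scatter). Compound 4 is therefore estimated at 12 ug/mL in this assay, between 6 ug/mL and 24 ug/mL.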

Compound 4, half-maximal inhibitory concentration: 3.97 ug/mL
Compound 4: middle estimate off by 3.0-fold (0.48 log units), on the high side; measured number below the stated range.
By their numbers in this assay, from the lowest: compounds 4, 1, 2 and 3 (each within the scatter of the next, the first and the last beyond it).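

In this assay the place of the trifluoromethyl on this phenyl ring now counts: 4-(trifluoromethyl)phenyl stands apart from both other placements, with a 4.8-fold lower number from compound 3 to compound 4 (0.68 log units; beyond the scatter) and a 2.5-fold lower number from compound 2 to compound 4 (0.41 log units; beyond the scatter) beyond the scatter. With 4-(trifluoromethyl)phenyl in place, the step of a 2.0-fold lower number from compound 1 to compound 4 (0.30 log units; within the scatter) shows that 2-fluorophenyl in place of 2,4-dichlorophenyl on the carbonyl carbon is not resolved. Nothing available explains the advantage of 4-(trifluoromethyl)phenyl.

Open, as far as these compounds go, is whether 4-cyanophenyl or 4-methoxyphenyl on the carbon with a double bond to nitrogen would match compound 4 3.97 ug/mL in this assay. Also open, from the compounds shown here alone, is whether the same order of placements holds with 2,4-dichlorophenyl on the carbonyl carbon.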